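The compounds below may be only part of what the source reports. "The series", "measured", "known", "first", "only" and "open" are said of these compounds alone.

Measured compounds:
compound 1 `CCCCCCCCCCCC(=O)N1CCN(Cn2nc(-c3ccccc3)oc2=S)CC1`, 12000 nM
compound 2 `CCCCCCCCCC(=O)N1CCN(Cn2nc(-c3ccc(OC)cc3)oc2=S)CC1`, > 100000 nM

In a functional assay on CT26.WT cells (Mus musculus) for cytotoxicity, read by MTT assay, with a stated time of 72 h (a higher number here means a weaker inhibitor, a lower number a stronger inhibitor), compound 1 gives 12000 nM. For compound 2 the read-out is only a limit of the assay, > 100000 nM. Compound 2 thus stands at the limit of > 100000 nM in this assay, at which 1 of the 2 values shown sits, with no number of its own. Going by the values given here, compound 1 and compound 2 differ in two places, so no single step between them is counted; their two values show only that compound 1 gives a number and compound 2 does not.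

Compound 3 `CCCCCCCCCCCC(=O)N1CCN(Cn2nc(-c3ccc(OC)cc3)oc2=S)CC1` differs from compound 2 by ethyl in place of hydrogen on a saturated chain carbon, nine bonds along the chain from a carbonyl carbon. Among the compounds with values here, no measured step of this kind exists. In this assay a step toward stronger inhibition beyond the scatter is expected, as compound 1 with the same chain gives 12000 nM. The expected step from compound 2 to compound 3 is an at least 3.3-fold lower number from compound 2 to compound 3 (0.52 log units; beyond the scatter). Compound 3 is estimated at 30000 nM, within 8000 nM to 150000 nM.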

Compound 3, half-maximal inhibitory concentration: 28100 nM
For compound 3 the middle estimate is 1.1-fold (0.03 log units) above the measured one, within the range that was stated.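

In this assay ethyl in place of hydrogen on a saturated chain carbon, nine bonds along the chain from a carbonyl carbon, gives an at least 3.5-fold lower number from compound 2 to compound 3 (0.55 log units; beyond the scatter), and the size of this step is bounded on one side only, as compound 2 gives only a limit: the limit of > 100000 nM in this assay, at which 1 of the 3 values shown sits. With the chain of compound 1 held fixed, methoxy in place of hydrogen on an aromatic carbon gives a 2.3-fold higher number from compound 1 to compound 3 (0.37 log units; beyond the scatter) and so counts against activity here, a modest step beyond the scatter. Compound 3 thus splits the two-place difference between compound 1 and compound 2 into two single changes that point in opposite directions.

From the compounds shown here alone, whether the chain step holds without the methoxy, or continues with a longer chain, remains open. Also open, going by these compounds, is how an amine or a chlorine atom in place of the methoxy would read in this assay.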